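Two inactive pieces joined in one amide

A few compounds are considered here, and "the series" means these few. Any claim that something is new, unique, unknown or untested is made for them only; others in the source may bear on it.

Measured so far:
compound 1 `O=C(Nc1ccc(Sc2nc3ccccc3s2)c(Cl)c1)c1ccccc1O` – > 100000 nM
compound 2 `COc1c(Br)cccc1C(=O)Nc1cccc(Cl)c1` – > 100000 nM
compound 3 `COc1ccc(Br)cc1C(=O)Nc1cccc(Cl)c1` – > 100000 nM

In an assay for inhibition of HSP60/HSP10 (Homo sapiens), with a stated time of 60 min (on this read-out higher numbers stand for weaker inhibition and lower numbers for stronger inhibition), compound 1 gives only the limit > 100000 nM, not a number. Compound 2 likewise stops at a limit. Compound 3 also stops at a limit. Thus compound 1 stands nowhere above the others; all three sit at the limit of > 100000 nM in this assay, at which 3 of the 3 values shown sit.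

Compound 4 `COc1ccc(Br)cc1C(=O)Nc1ccc(Sc2nc3ccccc3s2)c(Cl)c1` has not been measured in this assay. It differs from compound 1 by 5-bromo-2-methoxyphenyl in place of 2-hydroxyphenyl on a carbonyl carbon, so that the new acyl part matches that of compound 3, while the aniline part stays that of compound 1. With both parent parts at the limit, no step beyond the scatter is expected, and the step of a number no higher from compound 1 to compound 4 (the limit leaves the size open) is estimated to be small. Compound 4 is expected to give about 100000 nM, with a range from 20000 nM to 500000 nM.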

Compound 4, half-maximal inhibitory concentration: > 100000 nM
Compound 4 gave a limit, no number (the forecaster's own chance of this, stated with the estimate: 60%); the middle value sits exactly at the limit.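

Compound 1 and compound 4 both give only a limit in this assay, so the step between them cannot be read. The compounds shown leave open which structural change, if any, would give a measurable number: the limit of > 100000 nM in this assay, at which 4 of the 4 values shown sit.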